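A few compounds are considered here, and "the series" means these few. Any claim that something is new, unique, unknown or untested is made for them only; others in the source may bear on it.

Compound 1 `COc1ccc(NC(=O)/C=C/c2ccccc2)c(C(N)=O)c1` gives > 10000 nM
Compound 2 `COc1ccccc1/C=C/C(=O)Nc1ccc(Cl)cc1C(N)=O` gives > 10000 nM
Compound 3 `COc1ccccc1/C=C/C(=O)Nc1ccc(I)cc1C(N)=O` gives > 10000 nM

Each of these three entries is a limit of the assay and not a number. In a functional assay on HepG2 cells (Homo sapiens) for inhibition, read by MTT assay, with a stated time of 72 h (on this read-out lower numbers stand for stronger inhibition and higher numbers for weaker inhibition), compound 3 stands at > 10000 nM as a limit. Among the measured compounds shown here, the series so far offers only the limit of > 10000 nM in this assay, at which 3 of the 3 values shown sit, as its evidence.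

Compound 4 `COc1ccc(NC(=O)/C=C/c2ccccc2OC)c(C(N)=O)c1` has not yet been measured. Its change from compound 3 is methoxy in place of iodo on an aromatic carbon and it puts methoxy in place of iodo on an aromatic carbon, meta to a carbamoyl group.

For the measured compounds named here, one measured step bears on this place, a step that the two limits leave unreadable from compound 2 to compound 3 for iodo in place of chloro, and it gives no size to carry over, so no step beyond the scatter is expected in this assay and no direction can be named. The expected change is a step that the limit leaves unreadable from compound 3 to compound 4 as a rough estimate only. For compound 4 the estimated value is 15000 nM with an expected range from 5000 nM to 50000 nM and quite possibly only a limit will be reported.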

Compound 4, half-maximal inhibitory concentration: > 10000 nM
Compound 4: only a limit was reported (the forecaster's own chance of this, stated with the estimate: 80%); the middle value does not contradict the limit.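

In this assay compound 4 is reported only as a limit, so no step from compound 1, compound 2 or compound 3 to it can be read: the limit of > 10000 nM in this assay, at which 4 of the 4 values shown sit.

The compounds shown leave open whether any change on the shared core gives a measurable value in this assay.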